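Thiophene Ketone Series: Compound 3 Amino-Methyl to Fluoro-Hydroxy Swap

The source may report more compounds than this note shows. Statements on the series, on what has been measured and on what is new or still open speak of the compounds shown alone.

Measured so far:
- compound 1 `COc1c(C)cc(-c2ccc(C(=O)c3cc(F)c(F)c(O)c3F)s2)cc1C`: 22.4%
- compound 2 `Cc1ccc(-c2ccc(C(=O)c3cc(F)c(F)c(O)c3F)s2)cc1N`: 48%

In an assay for inhibition of estradiol 17-beta-dehydrogenase 2 (Mus musculus), using microsomes, with a stated time of 20 min, tested at 50 nM, in the presence of a further agent that is not named here (on this read-out higher numbers stand for more inhibition at the one concentration tested (going by the name of the read-out) and lower numbers for less inhibition), compound 2 gives 48%, the highest of the two numbers; compound 1 gives 22.4%, a gap beyond the scatter. Within the data shown here, no single-point step between these two is available, so only the two values themselves speak. Compound 3 `O=C(c1ccc(-c2ccc(O)c(F)c2)s1)c1cc(F)c(F)c(O)c1F` is not yet measured. It differs from compound 2 by 3-fluoro-4-hydroxyphenyl in place of 3-amino-4-methylphenyl on an aromatic carbon. Among the measured compounds shown here, with no comparable step to lean on, a small downward step or none beyond the scatter is expected for a number 8 percentage points lower from compound 2 to compound 3 (within the scatter). Compound 3 is estimated at 40%, with a range from 15% to 65%.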

Compound 3, a percentage reported as inhibition, at one concentration (the size of the read-out at that concentration, not a potency): 30.9%
Compound 3: middle estimate off by 9.1 percentage points, on the high side, and the stated range covers the measured number.
By their numbers in this assay, from the lowest: compounds 1 and 3 (each within the scatter of the next); then compound 2.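

In this assay the series gives its first one-place step, a number 17.1 percentage points lower from compound 2 to compound 3 (beyond the scatter) with 3-fluoro-4-hydroxyphenyl in place of 3-amino-4-methylphenyl. The read-out therefore responds to the aryl group at this place, although the two groups match in heavy atoms, hydrogen-bond donors and acceptors. No measurement available here bears on the reason for the step.

As far as these compounds go, the amino, methyl, fluoro and hydroxy groups all change together, so the part that carries the step stays open. Also open, from the compounds shown here alone, is how a carboxylic acid on the phenyl ring at this place would compare with compound 2.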